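A few compounds are considered here, and "the series" means these few. Any claim that something is new, unique, unknown or untested is made for them only; others in the source may bear on it.

Measured so far:
Compound 1, `COc1ccc(-c2cc(/C=C/C(=O)c3ccc(N)cc3)[nH]n2)cc1`, gives 90% in a functional assay on UO-31 cells (Homo sapiens) for cytotoxicity, read by sulforhodamine B assay, with a stated time of 48 h, tested at 0.01 uM; on this read-out higher numbers stand for a weaker effect at the one concentration tested and lower numbers for a stronger effect.
Compound 2, `COc1cc(-c2cc(/C=C/C(=O)c3ccc(N)cc3)[nH]n2)cc(OC)c1OC`, gives 91% in this assay.

Both numbers are high, which on this read-out means that at the single low concentration tested the cells are hardly affected by either compound. Compound 2 has the higher of the two numbers, but compound 1 sits only a sliver away from it, and that gap is inside the usual scatter of repeated measurements, so the two compounds cannot be told apart on what has been measured.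

The next compound, compound 3, `COc1ccc(-c2cc(/C=C/C(=O)c3ccc(N)cc3)[nH]n2)cc1OC`, differs from compound 2 in one place: hydrogen in place of methoxy on an aromatic carbon. Among the compounds with values here, no step between two measured compounds involves this kind of change, so there is no measured precedent to lean on. Given that compound 1 and compound 2, which differ in the same part of the molecule, give numbers within the scatter of each other, the expected step of a number 1 percentage points lower from compound 2 to compound 3 (within the scatter) is none beyond the scatter. Compound 3 is therefore estimated at 90%, with a range from 80% to 100%.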

Compound 3, a percentage reported as activity, at one concentration (the size of the read-out at that concentration, not a potency): 92%
For compound 3 the middle estimate is 2 percentage points below the measured one; the measured number falls inside the stated range.
By their numbers in this assay, from the lowest: compounds 1, 2 and 3 (each within the scatter of the next).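

In this assay, hydrogen in place of methoxy on an aromatic carbon, at a place ortho to a methoxy group and meta to a large group, gives a number 1 percentage points higher from compound 2 to compound 3 (within the scatter) and so does not separate the two compounds. Methoxy in place of hydrogen on an aromatic carbon gives a number 2 percentage points higher from compound 1 to compound 3 (within the scatter) and likewise separates nothing, so a single methoxy group on this six-membered aromatic ring, taken away in one pair and added in the other, shows no effect that can be told from the scatter at this one low concentration, something compounds 1 and 2 alone, which differ in more than one place, could not show. Nothing at hand explains why these swaps leave the read-out so flat.

From the compounds shown here alone, all three compounds carry only methoxy or hydrogen at these ring carbons, so what a fluorine atom, a hydroxyl group or an amine would do there remains open. Going by these compounds, with every number coming from a single low concentration, it also remains open whether the methoxy groups matter at concentrations where the cells are clearly affected.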